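The source may hold more compounds than are shown below. What is called first, only, known or untested is meant among the compounds shown, and "the series" means these compounds.

Measured compounds:
`COc1ccc(S(N)(=O)=O)cc1C(=O)Nc1cccc(-c2nncn2C(C)C)n1` compound 1, -1%
`COc1cc(C)c(S(N)(=O)=O)cc1C(=O)Nc1cccc(-c2nncn2C(C)C)n1` compound 2, 13%

In an assay for inhibition of serine/threonine-protein kinase 3 (Homo sapiens), tested at 1 uM (on this read-out higher numbers stand for more inhibition at the one concentration tested (going by the name of the read-out) and lower numbers for less inhibition), compound 1 gives -1%, the lower of the two numbers shown. Compound 2 gives 13%, and the step of a number 14 percentage points higher from compound 1 to compound 2 (beyond the scatter) went with methyl in place of hydrogen on an aromatic carbon. The unmeasured compound 3 `COc1ccc(S(C)(=O)=O)cc1C(=O)Nc1cccc(-c2nncn2C(C)C)n1` differs from compound 1 in methyl in place of amino on a sulfonyl sulfur. Within the data shown here, the one measured step concerns another place and another exchange, so no measured step bears directly on this change. The account therefore expects no step beyond the scatter in this assay, its estimated step being a number 4 percentage points higher from compound 1 to compound 3 (within the scatter). Compound 3 is expected to give 3%, within a range from -12% to 18%.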

Compound 3, a percentage reported as inhibition, at one concentration (the size of the read-out at that concentration, not a potency) in the serine/threonine-protein kinase 3 assay: -1%
For compound 3 the middle estimate is 4 percentage points above the measured one; measured number inside the range.
By their numbers in the serine/threonine-protein kinase 3 assay, from the lowest: compounds 1 and 3 (each within the scatter of the next); then compound 2.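

On a sulfonyl sulfur whose other neighbour is an aromatic carbon, methyl in place of amino gives no change at the digits printed from compound 1 to compound 3 (within the scatter) in the serine/threonine-protein kinase 3 assay, so removing the hydrogen-bond donor counted for amino leaves this read-out as it was. Both compounds stay close to zero there, which leaves little room to see a loss. The same exchange does separate the two compounds in a physicochemical assay for solubility, measured as thermodynamic solubility, at pH 7.4 (a lower number here means a less soluble compound, a higher number a more soluble compound), where compound 1 gives 1200 nM and compound 3 gives 5000 nM: the measured solubility of compound 1, 1200 nM, and of compound 3, 5000 nM, a 4.2-fold higher number (0.62 log units; beyond the scatter)

Going by these compounds, it remains open whether the exchange behaves alike with the methyl of compound 2 present. On these data alone, it is also open how an ethyl or dimethylamino group on the sulfonyl sulfur would read in either assay.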